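The source may hold more compounds than are shown below. What is called first, only, known or untested is meant among the compounds shown, and "the series" means these compounds.

Compound 1 `Cn1c(=O)c(=O)n(C2CCCC2)c2nc(N/N=C/c3ccc(Cl)cc3)ncc21` gives 6890 nM in a functional assay on A549 cells (Homo sapiens) for antiproliferative activity, read by MTT assay; a lower number here means a stronger inhibitor, a higher number a weaker inhibitor. Compound 2 `COc1cccc(/C=N/Nc2ncc3c(n2)n(C2CCCC2)c(=O)c(=O)n3C)c1` gives 27400 nM. Compound 3 `Cn1c(=O)c(=O)n(C2CCCC2)c2nc(N/N=C/c3ccc(C(F)(F)F)cc3)ncc21` gives 40600 nM.

Within the data shown here, compound 3 has the highest number of the three, but its gap to compound 2 lies within the scatter; only the step of a 5.9-fold higher number from compound 1 to compound 3 (0.77 log units; beyond the scatter) is beyond it. Compound 4 `Cn1c(=O)c(=O)n(C2CCCC2)c2nc(N/N=C/c3cccc(O)c3)ncc21` differs from compound 3 by 3-hydroxyphenyl in place of 4-(trifluoromethyl)phenyl on a carbon with a double bond to nitrogen. The nearest measured guide is compound 2, whose 3-methoxyphenyl group sits where the 3-hydroxyphenyl enters, and it showed a 1.5-fold higher number from compound 2 to compound 3 (0.17 log units; within the scatter). The trifluoromethyl group leaving here was itself tied to a 5.9-fold higher number from compound 1 to compound 3 (0.77 log units; beyond the scatter). The step of a 2.0-fold lower number from compound 3 to compound 4 (0.31 log units; beyond the scatter) is therefore expected to be a somewhat lower number, possibly within the scatter. Compound 4 is estimated at 20000 nM, with a range from 7000 nM to 60000 nM.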

Compound 4, half-maximal inhibitory concentration: > 100000 nM
Compound 4 gave a limit, no number (the forecaster's own chance of this, stated with the estimate: 10%); middle value at least 5.0-fold (0.69 log units) from the limit.
By their numbers in this assay, from the lowest: compound 1; then compounds 2 and 3 (each within the scatter of the next). At a limit, above all of these: compound 4.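

In this assay compound 4 gives > 100000 nM, which is a limit of the assay and not a number. Hydrogen in place of methyl on an oxygen on an aromatic ring is enough for an at least 3.6-fold higher number from compound 2 to compound 4 (0.56 log units; beyond the scatter), so this small change at the group on the carbon with a double bond to nitrogen can be read beyond the scatter. The other steps, an at least 2.4-fold higher number from compound 3 to compound 4 (0.39 log units; beyond the scatter) and an at least 14-fold higher number from compound 1 to compound 4 (1.16 log units; beyond the scatter), widen the spread this position covers, the latter being large.

The compounds shown leave open how an amine or a carboxylic acid in place of the hydroxyl would fare on this ring.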